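A few compounds are considered here, and "the series" means these few. Any claim that something is new, unique, unknown or untested is made for them only; others in the source may bear on it.

Measured so far in a functional assay on PC-3 cells (Homo sapiens) for antiproliferative activity, read by MTT assay; on this read-out higher numbers stand for weaker inhibition and lower numbers for stronger inhibition:
compound 1 `Cn1c(=O)c(=O)n(C2CCCC2)c2nc(N/N=C/c3ccc(O)c(F)c3)ncc21`: 85200 nM
compound 2 `COc1cccc(/C=N/Nc2ncc3c(n2)n(C2CCCC2)c(=O)c(=O)n3C)c1`: 20700 nM
compound 3 `Cn1c(=O)c(=O)n(C2CCCC2)c2nc(N/N=C/c3cccs3)ncc21`: 75600 nM

Compound 3 sits close to compound 1, the two numbers lying within the scatter of each other, while compound 2 is the one clearly apart, as the step of a 3.7-fold higher number from compound 2 to compound 3 (0.56 log units; beyond the scatter) shows. Compound 4 `COc1ccc(/C=N/Nc2ncc3c(n2)n(C2CCCC2)c(=O)c(=O)n3C)c(OC)c1` carries 2,4-dimethoxyphenyl in place of thiophen-2-yl on a carbon with a double bond to nitrogen. The step that bears on this change is a 3.7-fold higher number from compound 2 to compound 3 (0.56 log units; beyond the scatter), the only one in the set that exchanges the thiophen-2-yl for a methoxy-bearing phenyl; the step of a 4.1-fold lower number from compound 1 to compound 2 (0.61 log units; beyond the scatter) points the same way for a phenyl with one methoxy group. Among the measured compounds shown here, a second methoxy group has no precedent among the three measured compounds. A modest step downward is therefore expected, a 2.5-fold lower number from compound 3 to compound 4 (0.40 log units; beyond the scatter), in this assay. For compound 4 the estimate is 30000 nM, range 10000 nM to 90000 nM.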

Compound 4, half-maximal inhibitory concentration: > 100000 nM
Compound 4: no number, only a limit; the forecaster's own chance of this, stated with the estimate: 15%; at least 3.3-fold (0.52 log units) between middle value and limit.
By their numbers in this assay, from the lowest: compound 2; then compounds 3 and 1 (each within the scatter of the next). At a limit, above all of these: compound 4.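

In this assay compound 4 gives a limit and not a number: the limit of > 100000 nM in this assay, at which 1 of the 4 values shown sits. On the carbon with a double bond to nitrogen, a methoxy-bearing phenyl therefore does not by itself keep the stronger inhibition, since 2,4-dimethoxyphenyl falls clearly short of 3-methoxyphenyl: an at least 4.8-fold higher number from compound 2 to compound 4 (0.68 log units; beyond the scatter). Against the two weaker compounds the floors settle no order: an at least 1.3-fold higher number from compound 3 to compound 4 (0.12 log units; that floor lies within the scatter) and an at least 1.1-fold higher number from compound 1 to compound 4 (0.06 log units; that floor lies within the scatter).

Which methoxy group of the 2,4-dimethoxyphenyl goes with the loss remains open. Also open, going by these compounds, is how an amine or a carboxylic acid on the phenyl would read here.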